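The source may hold more compounds than are shown below. What is called first, only, known or untested is meant among the compounds shown, and "the series" means these compounds.

In a functional assay on HCT-116 cells (Homo sapiens) for antiproliferative activity, read by MTT assay, with a stated time of 48 h (a lower number here means a stronger inhibitor, a higher number a weaker inhibitor), compound 1 `CCCCCCCCC(CCO)n1cnc2c(Cl)ncnc21` gives 1650 nM and compound 2 `CCCCCCCCC(CCO)n1cnc2c(N)ncnc21` gives 11600 nM while compound 3 `CCCCCCCCC(CCO)n1cnc2c(N)nc(Cl)nc21` gives 21000 nM in the same test. Compound 2 sits at the high end of these numbers, within the scatter of compound 3 and clearly apart from compound 1. Within the data shown here, compound 4 `CCCCCCCCCCC(CCO)n1cnc2c(N)ncnc21` carries ethyl in place of hydrogen on a saturated chain carbon, nine bonds along the chain from an aromatic nitrogen as its only difference from compound 2. Neither a 7.0-fold higher number from compound 1 to compound 2 (0.85 log units; beyond the scatter) nor a 1.8-fold higher number from compound 2 to compound 3 (0.26 log units; within the scatter) touches the chain: both fall on an aromatic carbon and offer a scale but no direction. With only those steps to go on, no step beyond the scatter is expected in this assay for this change. For compound 4 the estimated value is 9000 nM with an expected range of 3500 nM to 22000 nM for now. The expected change is a 1.3-fold lower number from compound 2 to compound 4 (0.11 log units; within the scatter) and remains an estimate.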

Compound 4, half-maximal inhibitory concentration: 2590 nM
For compound 4 the middle estimate is 3.5-fold (0.54 log units) above the measured one, and the stated range ends above it.
By their numbers in this assay, from the lowest: compounds 1 and 4 (each within the scatter of the next); then compounds 2 and 3 (each within the scatter of the next).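

In this assay, the chain itself proves responsive: ethyl in place of hydrogen on a saturated chain carbon, nine bonds along the chain from an aromatic nitrogen, gives a 4.5-fold lower number from compound 2 to compound 4 (0.65 log units; beyond the scatter). Among these compounds, the earlier steps all fell on aromatic carbons, so this is the first sign that the number moves with a change this far along the chain, and it moves downward. Nothing at hand explains the shift.

On these data alone, whether a longer chain at this place lowers the number further or reverses the step remains open. Also open, as far as these compounds go, is whether the same ethyl change has a comparable effect with chloro in place of amino, as in compound 1.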